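The source may hold more compounds than are shown below. What is called first, only, known or untested is meant among the compounds shown, and "the series" means these compounds.

Among the compounds with values here, in a functional assay on MCF7 cells (Homo sapiens) for inhibition (on this read-out higher numbers stand for weaker inhibition and lower numbers for stronger inhibition), compound 1 `CC/C(=C(/c1ccc(/C=C/C(=O)O)cc1)c1cc2ccccc2[nH]1)c1ccccc1C` gives 33 nM, the second highest of the three numbers measured so far. Compound 3 `CC/C(=C(/c1ccc(/C=C/C(=O)O)cc1)c1cc2ccccc2[nH]1)c1ccc(F)cc1Cl` stands nearest with 39 nM, a 1.2-fold higher number from compound 1 to compound 3 (0.07 log units; within the scatter). Compound 2 `CC/C(=C(/c1ccc(/C=C/C(=O)O)cc1)c1cc2ccccc2[nH]1)c1ccccc1C#N` stands furthest with 9 nM, a 3.7-fold lower number from compound 1 to compound 2 (0.56 log units; beyond the scatter).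

Compound 4 `CC/C(=C(/c1ccc(/C=C/C(=O)O)cc1)c1cc2ccccc2[nH]1)c1ccc(Cl)cc1C(F)(F)F` has not yet been measured. It differs from compound 1 in one place: 4-chloro-2-(trifluoromethyl)phenyl in place of 2-methylphenyl on a double-bonded chain carbon bound to a double-bonded chain carbon and a saturated chain carbon.

Of the steps measured, the one most like it is a 1.2-fold higher number from compound 1 to compound 3 (0.07 log units; within the scatter), where a ring bearing chlorine and fluorine took the place of the 2-methylphenyl on the same carbon and the number hardly moved. The step of a 4.3-fold higher number from compound 2 to compound 3 (0.64 log units; beyond the scatter) shows that this ring fell short of the 2-cyanophenyl, but cyano plays no part in the change to compound 4. The trifluoromethyl is new to the series, so the measured steps give only thin guidance; what they do show is no reason to expect compound 4 to move beyond the scatter from compound 1 in either direction.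

Compound 4 is therefore expected to give 45 nM in this assay. The estimate for compound 4 is expected to span 15 nM to 130 nM. The step this estimate means is a 1.4-fold higher number from compound 1 to compound 4 (0.13 log units; within the scatter), expected to stay within the scatter.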

Compound 4, half-maximal inhibitory concentration: 4 nM
Compound 4: the middle estimate sits 11-fold (1.05 log units) above what was measured; the measured number lies below the stated range.
By their numbers in this assay, from the lowest: compound 4; then compound 2; then compounds 1 and 3 (each within the scatter of the next).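

In this assay, within the data shown here, the double-bonded chain carbon bound to a double-bonded chain carbon and a saturated chain carbon proves more responsive to ring substitution than the earlier compounds suggested: 4-chloro-2-(trifluoromethyl)phenyl gives an 8.3-fold lower number from compound 1 to compound 4 (0.92 log units; beyond the scatter), and also a 9.8-fold lower number from compound 3 to compound 4 (0.99 log units; beyond the scatter), so two rings that both carry halogen do not behave alike here. The new ring also goes past the 2-cyanophenyl, with a 2.3-fold lower number from compound 2 to compound 4 (0.35 log units; beyond the scatter), which shows that a nitrile is not needed for the lowest number among these compounds. No measurement at hand accounts for these steps.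

Whether the gain belongs to the trifluoromethyl, to the 4-chloro group or to the two together stays open, since no compound shown carries one without the other; a 2-(trifluoromethyl)phenyl ring and a 4-chloro-2-methylphenyl ring would separate them. Also open, from the compounds shown here alone, is how a methoxy group or an amine on this ring would compare with the trifluoromethyl on the same core.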